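Oxadiazole for isoxazole at the aryl position

The source may hold more compounds than are shown below. What is called first, only, known or untested is meant among the compounds shown, and "the series" means these compounds.

The study examines compound 2, `c1ccc(-c2cnoc2)c(NCC2=NCCN2)c1`, in a functional assay for activation of Alpha-1B adrenergic receptor (Homo sapiens), read by calcium flux; a lower number here means that less compound is needed, a higher number that more compound is needed for the effect. Compound 2 gives only a limit there, < 100000 nM, which is the assay's limit rather than a number. Its neighbour compound 1, `Cc1ncc(-c2ccccc2NCC2=NCCN2)o1`, likewise gives a limit in this assay, < 5020 nM. Among the measured compounds shown here, the only measured step, a step that the two limits leave unreadable from compound 1 to compound 2, cannot be sized because the limit of < 100000 nM in this assay, at which 1 of the 2 values shown sits, and the limit of < 5020 nM in this assay, at which 1 of the 2 values shown sits, are both limits rather than readings.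

The next compound, compound 3, `Cc1nc(-c2ccccc2NCC2=NCCN2)no1`, differs from compound 2 by 5-methyl-1,2,4-oxadiazol-3-yl in place of 1,2-oxazol-4-yl on an aromatic carbon. For the measured compounds named here, no measured step bears directly on this change, since the one step recorded is unreadable from its two limits. The evidence therefore sets no direction for this assay beyond what the limits allow, and a methyl-bearing five-membered heteroaryl in compound 1 is at least consistent with activity within the lower limit.

Compound 3 is therefore expected to give 4000 nM, within a range from 500 nM to 40000 nM. Relative to the limit of compound 2, the expected step that the limit leaves unreadable from compound 2 to compound 3 cannot be read as a true change.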

Compound 3, half-maximal effective concentration: 676 nM
For compound 3 the middle estimate is 5.9-fold (0.77 log units) above the measured one, within the range that was stated.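

The step from compound 2 to compound 3 cannot be read, as compound 2 gives only a limit: the limit of < 100000 nM in this assay, at which 1 of the 3 values shown sits. The step from compound 1 to compound 3 cannot be read either, as compound 1 also gives only a limit: the limit of < 5020 nM in this assay, at which 1 of the 3 values shown sits. The compounds shown leave open how far compound 3 truly differs from compound 1 and compound 2 in this assay.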